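Hydroxyalkyl in place of carbamoyl on the thioether chain

The compounds below may be only part of what the source reports. "The series", "measured", "known", "first", "only" and "open" are said of these compounds alone.

Compound 1: `CC(C)c1n[nH]c2c(NCc3ccc(-c4ccccn4)cc3)nc(SCC(O)C(F)(F)F)nc12` — 690 nM
Compound 2: `CC(C)c1n[nH]c2c(NCc3ccc(-c4ccccn4)cc3)nc(SCCNC(=N)N)nc12` — 390 nM
Compound 3: `CC(C)c1n[nH]c2c(NCc3ccc(-c4ccccn4)cc3)nc(SCC(N)=O)nc12` — 192 nM

The three measured compounds share one core and differ only in the group on a saturated chain carbon bound to a sulfur. In a functional assay on HT cells (Homo sapiens) for antiproliferative activity, read by fluorescence, with a stated time of 72 h (a lower number here means a stronger inhibitor of growth, a higher number a weaker inhibitor of growth), compound 3 gives the lowest number of the three: the step of a 2.0-fold lower number from compound 2 to compound 3 (0.31 log units; beyond the scatter) and the step of a 3.6-fold lower number from compound 1 to compound 3 (0.56 log units; beyond the scatter) both lie beyond the scatter, while a 1.8-fold lower number from compound 1 to compound 2 (0.25 log units; within the scatter) does not.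

Compound 4, `CCC(O)CSc1nc(NCc2ccc(-c3ccccn3)cc2)c2[nH]nc(C(C)C)c2n1`, has not been measured. It differs from compound 3 in that (1-hydroxypropyl in place of carbamoyl on a saturated chain carbon bound to a sulfur). Among the compounds with values here, the one measured step that bears on this change is a 3.6-fold lower number from compound 1 to compound 3 (0.56 log units; beyond the scatter), where a group with one hydrogen-bond donor and one acceptor on the same chain carbon gave way to carbamoyl and the number fell. Within the data shown here, compound 4 reverses that direction, though with a 1-hydroxypropyl rather than the 2,2,2-trifluoro-1-hydroxyethyl of compound 1, and no measured pair shows what that difference alone does. A modest rise in this assay is therefore expected, estimated as a 2.3-fold higher number from compound 3 to compound 4 (0.37 log units; beyond the scatter). Compound 4 is expected to give 450 nM, within a range from 200 nM to 1100 nM.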

Compound 4, concentration for 50% growth inhibition: 273 nM
For compound 4 the middle estimate is 1.6-fold (0.22 log units) above the measured one; low and high end bracket the measured number.
By their numbers in this assay, from the lowest: compounds 3, 4, 2 and 1 (each within the scatter of the next, the first and the last beyond it).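

In this assay, 1-hydroxypropyl in place of carbamoyl on a saturated chain carbon bound to a sulfur gives a 1.4-fold higher number from compound 3 to compound 4 (0.15 log units; within the scatter), so this exchange leaves no difference that can be told from the scatter, and the same holds for a 1.4-fold lower number from compound 2 to compound 4 (0.15 log units; within the scatter). Ethyl in place of trifluoromethyl gives a 2.5-fold lower number from compound 1 to compound 4 (0.40 log units; beyond the scatter), a comparison of the two hydroxy-bearing chains that no earlier pair offered, and it shows that the distance of compound 1 from the others goes with the trifluoromethyl rather than with the hydroxyl-bearing chain as such. Nothing available accounts for this difference.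

From the compounds shown here alone, whether an amine or a carboxylic acid on this chain carbon would stay in the same range remains open. So does the effect of a chain longer than 1-hydroxypropyl.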